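Swapping a Tetrazolylsulfanyl Arm for an Ethylpiperazinyl Arm

The source may hold more compounds than are shown below. What is called first, only, known or untested is meant among the compounds shown, and "the series" means these compounds.

Compound 1 `Cn1c(-c2ccc(NC(=O)CSc3nc4ccccc4s3)cc2)nc(-c2ccccc2)c1-c1ccccc1`: 82.7%
Compound 2 `Cn1nnnc1SCC(=O)Nc1ccc(-c2nc(-c3ccccc3)c(-c3ccccc3)n2C)cc1`: 89%

Of the compounds shown here, two with a shared core have been measured in a functional assay on HT-29 cells (Homo sapiens) for cytotoxicity, read by MTT assay, with a stated time of 24 h, tested at 80 ug/mL; a higher number here means a stronger effect of the compound at the concentration tested, a lower number a weaker effect. Among the measured compounds shown here, compound 2 holds the higher of the two numbers, but its only neighbour is compound 1, and the step of a number 6.3 percentage points higher from compound 1 to compound 2 (within the scatter) lies within the scatter, so the two stand level rather than in order. That single step is the whole of the comparative record, and it exchanged only the group carried on the sulfur while leaving the read-out essentially unchanged.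

Compound 3 `CCN1CCN(CC(=O)Nc2ccc(-c3nc(-c4ccccc4)c(-c4ccccc4)n3C)cc2)CC1` is not yet measured. It differs from compound 2 in one place: 4-ethylpiperazin-1-yl in place of (1-methyl-1H-tetrazol-5-yl)sulfanyl on a saturated chain carbon bound to a carbonyl carbon. Here the sulfur link itself and the aromatic heterocycle leave, and a six-membered non-aromatic ring enters directly on the chain carbon. For the measured compounds named here, the step of a number 6.3 percentage points higher from compound 1 to compound 2 (within the scatter) bears on this only loosely, since it kept the sulfanyl link intact; no measured step shows what removing that link does. The expected step is a number 17 percentage points lower from compound 2 to compound 3 (beyond the scatter), with the direction uncertain. Compound 3 is therefore estimated to give about 72%, within a broad range from 45% to 90%.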

Compound 3, a percentage reported as activity, at one concentration (the size of the read-out at that concentration, not a potency): 51.2%
The estimate for compound 3 lay 20.8 percentage points above the measured number; low and high end bracket the measured number.
By their numbers in this assay, from the lowest: compound 3; then compounds 1 and 2 (each within the scatter of the next).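

In this assay the chain carbon bound to a carbonyl carbon proves sensitive to the identity of its whole arm, with a number 37.8 percentage points lower from compound 2 to compound 3 (beyond the scatter) and a number 31.5 percentage points lower from compound 1 to compound 3 (beyond the scatter) on moving to 4-ethylpiperazin-1-yl. The earlier exchange on the sulfur (a number 6.3 percentage points higher from compound 1 to compound 2 (within the scatter)) had suggested that this part of the molecule tolerates change, but that held only while the sulfanyl link and an aromatic heterocycle stayed in place, and both sulfanyl-bearing compounds now lie well above compound 3. The data offer no measurement that accounts for this drop.

The change removed the sulfur link and the aromatic ring and brought in the non-aromatic ring all at once, so the compounds shown cannot say which of these matters, and a piperidin-4-yl ring held on the sulfanyl link would bear directly on that question. Going by these compounds, it also remains open whether the loss belongs to the ethylpiperazine alone or extends to other groups on the same chain carbon, such as morpholin-4-yl or a simple diethylamino group.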